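Exchanging the Small Selenium Group on a Potent Compound

A few compounds are considered here, and "the series" means these few. Any claim that something is new, unique, unknown or untested is made for them only; others in the source may bear on it.

For the measured compounds named here, compound 2 (`COc1ccc(N(C)c2nc(C)nc3ccccc23)cc1[Se]C`) gives 3 nM in a functional assay on LoVo cells (Homo sapiens) for inhibition, read by MTT assay, with a stated time of 48 h (on this read-out higher numbers stand for weaker inhibition and lower numbers for stronger inhibition), and holds the lower of the two numbers known so far, while compound 1 (`COc1ccc(N(C)c2nc(C)nc3ccccc23)cc1C(=O)NCC[Se]C#N`) gives 561 nM there. Compound 3 (`COc1ccc(N(C)c2nc(C)nc3ccccc23)cc1C[Se]C#N`) differs from compound 2 at one place, on an aromatic carbon ortho to a methoxy group: a group of 4 heavy atoms (2 carbon, 1 nitrogen, 1 selenium; no ring) in place of a group of 2 heavy atoms (1 carbon, 1 selenium; no ring), on an aromatic carbon is the change. Going by the values given here, only one measured step bears on it. That step is a 190-fold lower number from compound 1 to compound 2 (2.27 log units; beyond the scatter) and is large and beyond the scatter. Compound 1 also carries a nitrile on selenium, but on a longer chain than the group entering compound 3, so only part of that large step is expected to return. In this assay the expected change is a 13-fold higher number from compound 2 to compound 3 (1.12 log units; beyond the scatter) toward weaker inhibition. For compound 3 the estimate is 40 nM with an expected range from 6 nM to 280 nM in this read-out.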

Compound 3, half-maximal inhibitory concentration: 277 nM
Compound 3: middle estimate off by 6.9-fold (0.84 log units), on the low side; the measured number falls inside the stated range.
By their numbers in this assay, from the lowest: compound 2; then compound 3; then compound 1.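

In this assay, placing the nitrile-bearing selenium group on this aromatic carbon, ortho to a methoxy group, gives a 92-fold higher number from compound 2 to compound 3 (1.97 log units; beyond the scatter) in place of the small selenium group, so this position does not accept the exchange without a large rise in the number. The much smaller group of compound 3 also stays close to the long chain of compound 1, with a 2.0-fold lower number from compound 1 to compound 3 (0.31 log units; beyond the scatter) as only a modest step, so shortening the chain recovers little of the distance to compound 2. Nothing measured here accounts for either step.

Open, on these data alone, is which part of the entering group carries the large step, as it differs from the small selenium group in both its nitrile and its carbon link to the aromatic ring. A nitrile bound directly through selenium to the aromatic carbon, or a methylthio group at this place, would separate the nitrile and the selenium from the rest of the change.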